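The compounds below may be only part of what the source reports. "The series", "measured", "known", "first", "only" and "open" are said of these compounds alone.

Measured so far in a functional assay on K562 cells (Homo sapiens) for antiproliferative activity, read by MTT assay, with a stated time of 48 h; on this read-out lower numbers stand for stronger inhibition and higher numbers for weaker inhibition:
compound 1, `COC(=O)[C@H](CC(C)C)NC(=O)c1ccc(Oc2nc3ccccc3nc2C)cc1`, gives 22600 nM;
compound 2, `CC[C@@H](C)[C@H](NC(=O)c1ccc(Oc2nc3ccccc3nc2C)cc1)C(=O)OC`, gives 38300 nM;
compound 3, `CC[C@@H](C)[C@H](NC(=O)c1ccc(Oc2nc3ccccc3nc2NC(C)(C)C)cc1)C(=O)O`, gives 18300 nM.

Compounds 1 and 2 share one core, compound 3 carries another; the difference between the two cores is not broken down here. Compound 1 differs from compound 2 by isobutyl in place of sec-butyl on a saturated chain carbon bound to an amide-type nitrogen and a carbonyl carbon, a change that gave a 1.7-fold lower number from compound 2 to compound 1 (0.23 log units; within the scatter). Compound 4, `CC(C)C[C@H](NC(=O)c1ccc(Oc2nc3ccccc3nc2NC(C)(C)C)cc1)C(=O)O`, has not yet been tested in this assay; it differs from compound 3 by isobutyl in place of sec-butyl on a saturated chain carbon bound to an amide-type nitrogen and a carbonyl carbon, the same change made at the same place.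

Because the earlier step of a 1.7-fold lower number from compound 2 to compound 1 (0.23 log units; within the scatter) was small, the step from compound 3 to compound 4 is expected to be of similar modest size, a 1.5-fold lower number from compound 3 to compound 4 (0.18 log units; within the scatter). Compound 4 is accordingly estimated at 12000 nM, with a likely range from 5000 nM to 30000 nM.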

Compound 4, half-maximal inhibitory concentration: 42300 nM
Compound 4: middle estimate off by 3.5-fold (0.55 log units), on the low side, outside the stated range (above it).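

Replacing sec-butyl with isobutyl in this assay gave a 2.3-fold higher number from compound 3 to compound 4 (0.36 log units; beyond the scatter). Set beside the earlier step, this shows that the change does not carry over unchanged between these two cores: the same change on two cores in this assay, a 1.7-fold lower number (0.23 log units; within the scatter) from compound 2 to compound 1 and a 2.3-fold higher number (0.36 log units; beyond the scatter) from compound 3 to compound 4, 3.9-fold (0.59 log units) apart, beyond the scatter of two such steps It does not show which structural difference matters, as compound 1 and compound 2 carry a methyl ester and a methyl group, while compound 3 and compound 4 carry a carboxylic acid and a tert-butylamino group.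

The compounds shown leave open how each of those two differences acts alone, which a pair combining the carboxylic acid with the methyl group could help to separate. They also leave open how a straight butyl chain would behave at the same place.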